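A few compounds are considered here, and "the series" means these few. Any claim that something is new, unique, unknown or untested is made for them only; others in the source may bear on it.

Among the measured compounds shown here, in a functional assay on MCF7 cells (Homo sapiens) for inhibition, read by MTT assay, with a stated time of 72 h (on this read-out higher numbers stand for weaker inhibition and lower numbers for stronger inhibition), three compounds have numbers so far. Compound 1 (`Cc1cc(Nc2ccn(Cc3cccc4ccccc34)n2)n2nc(SCc3ccc(Br)cc3)nc2n1`) gives 4310 nM, compound 2 (`Cc1cc(Nc2cc(C(C)(C)C)[nH]n2)n2nc(SCc3ccc(Br)cc3)nc2n1`) gives 7290 nM, and compound 3 (`Cc1cc(Nc2cc(-c3ccccc3)[nH]n2)n2nc(SCCCc3ccccc3)nc2n1`) gives 3900 nM. Compound 3 stands within the usual scatter of both other compounds, so these three results cannot be ranked against each other.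

The next compound departs from compound 3 at a single place. Compound 4 (`Cc1cc(Nc2cc(-c3ccccc3)[nH]n2)n2nc(SCc3csc4ccccc34)nc2n1`) carries 1-benzothiophen-3-yl in place of phenethyl on a saturated chain carbon bound to a sulfur. Read one bond further out, 3-phenylpropyl gives way to (1-benzothiophen-3-yl)methyl.

For the measured compounds named here, no two measured compounds differ in only one place, so the data hold no direct measure of what such a change does in this assay. The expectation therefore rests on the narrow spread seen so far: compound 1 at 4310 nM and compound 3 at 3900 nM lie within the scatter of each other, although they differ in more than one place. No step beyond the scatter is expected, and neither direction is clearly favoured. The estimated change is a 1.1-fold lower number from compound 3 to compound 4 (0.05 log units; within the scatter), a step expected to stay within the scatter. Compound 4 is estimated at 3500 nM, with an expected range from 1300 nM to 9000 nM.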

Compound 4, half-maximal inhibitory concentration: 3470 nM
For compound 4 the middle estimate is 1.0-fold (0.00 log units) above the measured one; the range from low to high includes it.
By their numbers in this assay, from the lowest: compounds 4, 3, 1 and 2 (each within the scatter of the next, the first and the last beyond it).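

In this assay, the data now hold their first step between compounds that differ in one place: a 1.1-fold lower number from compound 3 to compound 4 (0.05 log units; within the scatter). It gives a direct measure at the saturated chain carbon bound to a sulfur, where (3-phenylpropyl)sulfanyl gives way to ((1-benzothiophen-3-yl)methyl)sulfanyl and the one six-membered aromatic ring of carbon only is joined by one five-membered aromatic ring with 1 hetero atom, yet the number stays within the scatter, so this exchange of two quite different aromatic groups shows no measurable effect in this read-out. Nothing available explains why the two groups read alike.

Going by these compounds, with a single step, and two aromatic groups as the only ones compared at this position, it remains open whether any group placed here can move the number beyond the scatter, for instance an amine or a carboxylic acid on the chain, or a chain longer than 3-phenylpropyl. On these data alone, it is also open whether the same exchange would stay within the scatter if the rest of compound 3 were different.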